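A few compounds are considered here, and "the series" means these few. Any claim that something is new, unique, unknown or untested is made for them only; others in the source may bear on it.

In a functional assay on CCRF-CEM cells (Homo sapiens) for antiproliferative activity, read by fluorescence and resazurin assay, with a stated time of 48 h (a lower number here means a stronger inhibitor, a higher number a weaker inhibitor), compound 3 `Cc1noc(NS(=O)(=O)c2ccc(NC(=O)c3cc4ccccc4oc3=O)cc2)c1C` gives 26600 nM. Compound 1 `Cc1noc(NS(=O)(=O)c2ccc(NC(=O)c3cc4ccc(O)cc4oc3=O)cc2)c1C` differs from it only by hydroxy in place of hydrogen on an aromatic carbon and in this assay compound 1 gives 21500 nM, so that change made a 1.2-fold lower number from compound 3 to compound 1 (0.09 log units; within the scatter). Compound 2 `CCOc1ccc2nc(Cl)c(/C=N/NC(=O)c3cc4ccccc4oc3=O)cc2c1` rests on another core, and how the two cores differ is not broken down here. In this assay compound 2 gives 6320 nM, the lowest of the three numbers and beyond the scatter from both others. Compound 4 `CCOc1ccc2nc(Cl)c(/C=N/NC(=O)c3cc4ccc(O)cc4oc3=O)cc2c1` is still to be measured; it differs from compound 2 by hydroxy in place of hydrogen on an aromatic carbon, the same change at the same kind of place. The step of a 1.2-fold lower number from compound 2 to compound 4 (0.08 log units; within the scatter) is expected to be similarly small, because the earlier step of a 1.2-fold lower number from compound 3 to compound 1 (0.09 log units; within the scatter) lay within the scatter. Compound 4 is therefore estimated at 5300 nM, with a likely range from 2500 nM to 12000 nM.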

Compound 4, half-maximal inhibitory concentration: 17100 nM
Estimate against measurement, compound 4: 3.2-fold (0.51 log units) below, outside the stated range (above it).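

In this assay, hydroxy in place of hydrogen on an aromatic carbon gave a 2.7-fold higher number from compound 2 to compound 4 (0.43 log units; beyond the scatter), so the step seen on one core did not carry over to the other: the same change on two cores in this assay, a 1.2-fold lower number (0.09 log units; within the scatter) from compound 3 to compound 1 and a 2.7-fold higher number (0.43 log units; beyond the scatter) from compound 2 to compound 4, 3.3-fold (0.52 log units) apart, beyond the scatter of two such steps. Across these two pairs, the result of this change therefore depended on the core that carried it, and the small step on the core of compound 3 was no safe guide to the core of compound 2. This does not show which part of the cores accounts for the gap, nor does it give a rule for any third core.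

On these data alone, it remains open whether a methoxy group or an amine on the same aromatic carbon would follow the hydroxy group on either core. As far as these compounds go, how hydroxy behaves on other aromatic carbons of these cores also remains open.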